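The source may hold more compounds than are shown below. What is called first, only, known or untested is meant among the compounds shown, and "the series" means these compounds.

In a functional assay on SK-MEL-5 cells (Homo sapiens) for antiproliferative activity (on this read-out higher numbers stand for weaker inhibition of growth and lower numbers for stronger inhibition of growth), compound 1 `COCCCCCCCCCCCCCCC/C=C1/CC(CO)(COC(=O)C(C)(C)C)OC1=O` gives 2.13 ug/mL and compound 2 `COCCCCCCCCCCC/C=C1\CC(CO)(COC(=O)C(C)(C)C)OC1=O` gives 2.81 ug/mL, two values within the usual scatter of each other. Compound 3 `CCCCCCCCC(O)CCCCCC/C=C1\CC(CO)(COC(=O)C(C)(C)C)OC1=O` gives only a limit, > 10 ug/mL, and not a number. The evidence on it is therefore (the limit of > 10 ug/mL in this assay, at which 1 of the 3 values shown sits). Among the measured compounds shown here, the one measured step bearing on what follows is an at least 3.5-fold higher number from compound 2 to compound 3 (0.55 log units; beyond the scatter), which lies beyond the scatter and is itself bounded by that limit.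

Compound 4 `CC(C)(C)C(=O)OCC1(CO)C/C(=C\CCCCCCCCCCCCCCC=O)C(=O)O1` differs from compound 3 by 8-formyloctyl in place of 1-hydroxynonyl on a saturated chain carbon, six bonds along the chain from a double-bonded chain carbon, with 8-formyloctyl in place of 1-hydroxynonyl on a saturated chain carbon. Compound 4 no longer carries the 1-hydroxynonyl that came with an at least 3.5-fold higher number from compound 2 to compound 3 (0.55 log units; beyond the scatter), so a move toward stronger inhibition of growth is expected in this assay. For the measured compounds named here, its size is uncertain, as compound 3 has no exact number and no measured compound carries 8-formyloctyl. The expected change is an at least 2.0-fold lower number from compound 3 to compound 4 (0.30 log units; that floor lies within the scatter). For compound 4 the estimated value is 5 ug/mL, with an expected range of 1.5 ug/mL to 15 ug/mL.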

Compound 4, concentration for 50% growth inhibition: > 10 ug/mL
Compound 4 was reported as a limit; the forecaster's own chance of this, stated with the estimate: 30%; at least 2.0-fold (0.30 log units) between middle value and limit.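

With 8-formyloctyl in place of 1-hydroxynonyl at this position, six bonds along the chain from a double-bonded chain carbon, the number in this assay does not return to the earlier level: the step is an at least 3.5-fold higher number from compound 2 to compound 4 (0.55 log units; beyond the scatter) in which 3-formylpropyl stands in place of methoxy. The weaker inhibition of growth seen with compound 3 is therefore not confined to the chain carrying 1-hydroxynonyl, as a chain with 8-formyloctyl shows it too. The step between the two limits cannot be read, and neither compound can be ranked against the other: the limit of > 10 ug/mL in this assay, at which 2 of the 4 values shown sit.

As far as these compounds go, how far compound 3 and compound 4 lie past the limit stays open. So does whether a chain carrying a carboxylic acid or an amine in place of methoxy would keep the growth inhibition of compound 1 and compound 2.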